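Bromo to fluoro on the benzyl ring of compound 3

The compounds below may be only part of what the source reports. "The series", "measured", "known", "first", "only" and "open" are said of these compounds alone.

Compound 3 `Cn1c(=O)c2[nH]c(-c3ccc(S(=O)(=O)N4CCN(Cc5ccc(Br)cc5)CC4)cc3)cc2n(C)c1=O` holds the lowest number of the three measured in an assay on HEK293 cells for displacement of a labelled ligand from adenosine receptor A2b (Homo sapiens) (a lower number here means a stronger inhibitor, a higher number a weaker inhibitor), at 1 nM. Compound 1 `Cn1c(=O)c2[nH]c(-c3ccc(S(=O)(=O)N4CCN(Cc5ccc(Cl)s5)CC4)cc3)cc2n(C)c1=O` gives 4 nM, and compound 2 `CCn1c(=O)c2[nH]c(-c3ccc(S(=O)(=O)NC4CCN(Cc5ccc(F)cc5)CC4)cc3)cc2n(CC)c1=O` gives 12 nM. For the measured compounds named here, the only step that changes one place, a 4.0-fold lower number from compound 1 to compound 3 (0.60 log units; beyond the scatter), swaps the ring on the benzyl carbon rather than a substituent on that ring. Compound 4 `Cn1c(=O)c2[nH]c(-c3ccc(S(=O)(=O)N4CCN(Cc5ccc(F)cc5)CC4)cc3)cc2n(C)c1=O` differs from compound 3 by fluoro in place of bromo on an aromatic carbon. Going by the values given here, no measured pair covers a halogen swap on the phenyl; compound 2 carries the 4-fluorobenzyl but differs at several further places, so its value bears only loosely here. For compound 4 a modest rise in this assay is expected, a 3.0-fold higher number from compound 3 to compound 4 (0.48 log units; beyond the scatter). Compound 4 is thus estimated at 3 nM, within 1 nM to 10 nM.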

Compound 4, half-maximal inhibitory concentration: 10 nM
For compound 4 the middle estimate is 3.3-fold (0.52 log units) below the measured one, within the range that was stated.
By their numbers in this assay, from the lowest: compound 3; then compound 1; then compounds 4 and 2 (each within the scatter of the next).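

In this assay, for the compounds shown here, the halogen on this aromatic carbon carries real weight: fluoro in place of bromo gives a 10-fold higher number from compound 3 to compound 4 (1.00 log units; beyond the scatter), the first measured change of a substituent on the phenyl ring. The swap away from 5-chlorothiophen-2-yl now runs the other way with 4-fluorophenyl, at a 2.5-fold higher number from compound 1 to compound 4 (0.40 log units; beyond the scatter), so the order of these rings here depends on the halogen carried. Nothing available explains the gap between bromo and fluoro. On these data alone, whether chloro, iodo, methyl or methoxy on this carbon would sit nearer bromo or fluoro stays open.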